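Sulfonylurea aryl variation: from compound 3 to compound 4

The source may report more compounds than this note shows. Statements on the series, on what has been measured and on what is new or still open speak of the compounds shown alone.

Measured so far:
compound 1, `Cc1ncc(S(=O)(=O)NC(=O)NC/C=C2\CCCc3cnn(Cc4ccc(Cl)cc4Cl)c32)s1`, 7 nM
compound 2, `COc1ccccc1S(=O)(=O)NC(=O)NC/C=C1\CCCc2cnn(Cc3ccc(Cl)cc3Cl)c21`, 62 nM
compound 3, `O=C(NC/C=C1\CCCc2cnn(Cc3ccc(Cl)cc3Cl)c21)NS(=O)(=O)c1ccc(Cl)cc1`, 4 nM

All three values come from an assay on isolated protein for displacement of a labelled ligand from prostaglandin E2 receptor EP3 subtype (Homo sapiens), read by scintillation counting, with a stated time of 2 h; a lower number here means a stronger inhibitor, a higher number a weaker inhibitor. Compound 3 gives the lowest number of the three; compound 1 lies nearest to it, and the two are within the scatter of each other, as the step of a 1.8-fold lower number from compound 1 to compound 3 (0.24 log units; within the scatter) shows. Compound 2 is the furthest away, the step of a 16-fold lower number from compound 2 to compound 3 (1.19 log units; beyond the scatter) being large. The remaining step, an 8.9-fold higher number from compound 1 to compound 2 (0.95 log units; beyond the scatter), is modest.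

The next compound, compound 4, is `COc1ccc(Cl)cc1S(=O)(=O)NC(=O)NC/C=C1\CCCc2cnn(Cc3ccc(Cl)cc3Cl)c21`. Relative to compound 3 the change is 5-chloro-2-methoxyphenyl in place of 4-chlorophenyl on a sulfonyl sulfur. The group entering carries the 2-methoxyphenyl pattern of compound 2 with an added chlorine, so the step that bears most directly on it is a 16-fold lower number from compound 2 to compound 3 (1.19 log units; beyond the scatter), which ran the other way. How much of that cost the added chlorine recovers cannot be read from the three compounds measured; the step of a 1.8-fold lower number from compound 1 to compound 3 (0.24 log units; within the scatter) shows only that a chlorophenyl and a methyl-thiazolyl give numbers within the scatter of each other.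

The expectation in this assay is therefore a higher number for compound 4 than for compound 3, by a step of moderate size, a 6.3-fold higher number from compound 3 to compound 4 (0.80 log units; beyond the scatter). For compound 4 the estimate in this assay is 25 nM, with a range from 8 nM to 80 nM.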

Compound 4, inhibition constant: 3 nM
Compound 4: the middle estimate sits 8.3-fold (0.92 log units) above what was measured; the measured number lies below the stated range.
By their numbers in this assay, from the lowest: compounds 4, 3 and 1 (each within the scatter of the next, the first and the last beyond it); then compound 2.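

In this assay, among these compounds, the single change of chloro in place of hydrogen on an aromatic carbon gives a 21-fold lower number from compound 2 to compound 4 (1.32 log units; beyond the scatter) and so shows that the 2-methoxyphenyl pattern on the sulfonyl sulfur does not by itself fix a high number; compound 2 is the only one of the four that stands apart. The 5-chloro-2-methoxyphenyl group and the 4-chlorophenyl group cannot be told apart here, with a 1.3-fold lower number from compound 3 to compound 4 (0.12 log units; within the scatter) as the step between them, whereas against the 2-methyl-1,3-thiazol-5-yl group the new group gives a 2.3-fold lower number from compound 1 to compound 4 (0.37 log units; beyond the scatter) as a modest step. No measurement in hand accounts for the size of the chlorine step.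
As far as these compounds go, whether the methoxy group contributes anything once the chlorine is present stays open, as does whether the chlorine itself is needed or a fluoro, a trifluoromethyl or a nitrile on the same ring would serve equally. From the compounds shown here alone, how an amine or a carboxylic acid on this aryl ring would fare at the sulfonyl sulfur also stays open.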